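Methyl-to-hydrogen step on the core nitrogen, second occurrence

The source may report more compounds than this note shows. Statements on the series, on what has been measured and on what is new or still open speak of the compounds shown alone.

Measured so far, all in an ADME assay on MT4 cells (Homo sapiens) for cytotoxicity, read by MTT assay, with a stated time of 96 h; a higher number here means that more compound is tolerated, a lower number that less compound is tolerated:
compound 1 `CC(=O)Nc1ccc(-c2nc3cc(C(F)(F)F)ccc3n2C)cc1` gives 15000 nM
compound 2 `CC(=O)Nc1ccc(-c2nc3cc(C(F)(F)F)ccc3[nH]2)cc1` gives 19000 nM
compound 3 `Cn1c(-c2ccc(NC(=O)CN3CCN(c4ccccc4)CC3)cc2)nc2cc(C(F)(F)F)ccc21` gives 1500 nM

Compound 4 `O=C(CN1CCN(c2ccccc2)CC1)Nc1ccc(-c2nc3cc(C(F)(F)F)ccc3[nH]2)cc1` is not yet measured. It differs from compound 3 by hydrogen in place of methyl on an aromatic nitrogen. The same change has been made once before, from compound 1 to compound 2, where it gave a 1.3-fold higher number from compound 1 to compound 2 (0.10 log units; within the scatter). The two cores are not alike: compound 3 differs from compound 1 by 4-phenylpiperazin-1-yl in place of hydrogen on a saturated chain carbon bound to a carbonyl carbon, and that change gave a 10-fold lower number from compound 1 to compound 3 (1.00 log units; beyond the scatter). The two place descriptions read the same word for word, so the change from compound 3 to compound 4 is the same change, made on a compound that already sits at the lowest of the three numbers.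

Resting on compound 1 and compound 2 and their step of a 1.3-fold higher number from compound 1 to compound 2 (0.10 log units; within the scatter), which stayed within the scatter, the expected step is a 1.3-fold higher number from compound 3 to compound 4 (0.10 log units; within the scatter). Compound 4 is therefore estimated at 1900 nM, with a range from 900 nM to 4500 nM in this assay.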

Compound 4, half-maximal cytotoxic concentration: 900 nM
For compound 4 the middle estimate is 2.1-fold (0.32 log units) above the measured one; the range from low to high includes it.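

In this assay, hydrogen in place of methyl on an aromatic nitrogen gives a 1.7-fold lower number from compound 3 to compound 4 (0.22 log units; within the scatter), and the change carries from one core to the other with no difference that can be told apart: the same change on two cores in this assay, a 1.3-fold higher number (0.10 log units; within the scatter) from compound 1 to compound 2 and a 1.7-fold lower number (0.22 log units; within the scatter) from compound 3 to compound 4, 2.1-fold (0.32 log units) apart, within the scatter of two such steps. Neither step separates its two compounds, with or without the 4-phenylpiperazin-1-yl group, so the opposite directions of the two steps carry no weight. This rests on two pairs only and does not show how the change would behave on any other core.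

The compounds shown leave open what an ethyl group or a longer chain on that aromatic nitrogen would give. They also leave open whether the step would stay the same with a morpholine or a simple dialkylamine in place of the 4-phenylpiperazin-1-yl group.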